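Replacing the amide substituent of compound 3

The compounds below may be only part of what the source reports. "The series", "measured", "known", "first", "only" and "open" are said of these compounds alone.

Values measured in a physicochemical assay for solubility, read by spectrophotometry, measured as kinetic solubility, at pH 8, tested at 500 uM; a higher number here means a more soluble compound, a lower number a less soluble compound:
- compound 1 `CNS(=O)(=O)c1ccccc1Nc1cc(-c2ccc3ccn(C)c3c2)c2nccnc2c1` gives 2 ug/mL
- compound 2 `CN(C)S(=O)(=O)c1ccccc1Nc1cc(-c2ccc3ccn(C)c3c2)c2nccnc2c1` gives 2 ug/mL
- compound 3 `Cn1cc(CNC(=O)c2ccncc2Nc2cc(-c3ccc4ccn(C)c4c3)c3nccnc3c2)cn1` gives 127 ug/mL

Compound 3 has the highest of the three numbers, and its gap to each of compound 1 and compound 2 lies beyond the scatter. The next structure is compound 4 `CN1CC(NC(=O)c2ccncc2Nc2cc(-c3ccc4ccn(C)c4c3)c3nccnc3c2)CCC1=O`, which carries 1-methyl-6-oxopiperidin-3-yl in place of (1-methyl-1H-pyrazol-4-yl)methyl on an amide-type nitrogen.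

Among the measured compounds shown here, only one measured step differs in a single place, no change at the digits printed from compound 1 to compound 2 (within the scatter), with methyl in place of hydrogen on a sulfonamide nitrogen. That step lies within the scatter, but it sits elsewhere and involves another kind of change, so it offers only weak guidance. For the measured compounds named here, no measured step covers the amide-type nitrogen. The anchor is therefore compound 3 at 127 ug/mL, and no shift beyond the scatter is expected in this assay. The expected change is a 1.1-fold higher number from compound 3 to compound 4 (0.04 log units; within the scatter), an estimate with no firm direction. Compound 4 is estimated at 140 ug/mL, with an expected range from 60 ug/mL to 260 ug/mL, when measured.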

Compound 4, solubility: 253 ug/mL
For compound 4 the middle estimate is 1.8-fold (0.26 log units) below the measured one; the measured number falls inside the stated range.
By their numbers in this assay, from the lowest: compounds 1 and 2 (each within the scatter of the next); then compounds 3 and 4 (each within the scatter of the next).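

In this assay, exchanging (1-methyl-1H-pyrazol-4-yl)methyl for 1-methyl-6-oxopiperidin-3-yl on the amide-type nitrogen gives a 2.0-fold higher number from compound 3 to compound 4 (0.30 log units; within the scatter). Among the compounds shown here, this is the first reading at this position, and it shows that a one-ring, non-aromatic, six-membered group bearing a carbonyl and an aromatic five-membered group on a methylene can stand here without a step beyond the scatter, so the read-out does not separate these two groups. Nothing available on these compounds explains this result.

On these data alone, whether this holds for other kinds of group on the same nitrogen remains open, for instance a simple amine such as piperidine, a carboxylic acid or a longer open chain. It is also open whether the amide hydrogen itself matters, as a methyl on this nitrogen does not appear among these compounds.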